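The source may report more compounds than this note shows. Statements on the series, on what has been measured and on what is new or still open speak of the compounds shown alone.

This account follows a small set of compounds that share one core. Compound 1 has the structure `CCOC(=O)CSc1nnc(COc2ccccc2C2=NOC(c3ccc(Cl)cc3Cl)C2)n1NC(=O)c1ccccc1`. In an ADME assay (MDM cells, Homo sapiens) for cytotoxicity, read by resazurin assay, with a stated time of 3 days (a lower number here means a stronger inhibitor, a higher number a weaker inhibitor), compound 1 gives "not determined" (no result reported), so there is no single number on which compound 1 can be placed, and it stands nowhere on the numbers shown. Going by the values given here, compound 2, with the structure `CCCCSc1nnc(COc2ccccc2C2=NOC(c3ccc(Cl)cc3Cl)C2)n1NC(=O)CCl`, is the only member of the set with a result: in this assay compound 2 gives 2.8 ug/mL. Compound 3, with the structure `CSc1nnc(COc2ccccc2C2=NOC(c3ccc(Cl)cc3Cl)C2)n1NC(=O)c1ccccc1`, has not yet been measured. The change from compound 1 to compound 3 is this: hydrogen in place of ethoxycarbonyl on a saturated chain carbon bound to a sulfur. Among the compounds with values here, compound 1 has no result to start from, and no pair of measured compounds shows what this change does, so the direction of the step in this assay cannot be read from the data. Within the data shown here, the one anchor is compound 2 on the same core, and from that anchor a small step in either direction, or none beyond the scatter, would be expected. Compound 3 is expected to give 5 ug/mL in this assay, with a range from 1.5 ug/mL to 20 ug/mL.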

Compound 3, half-maximal inhibitory concentration: 2.2 ug/mL
Estimate against measurement, compound 3: 2.3-fold (0.36 log units) above; low and high end bracket the measured number.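

Going by these compounds alone, compound 1 has no number in this assay, so no step to compound 3 can be read from this result. The compounds shown leave open what replacing ((ethoxycarbonyl)methyl)sulfanyl with methylsulfanyl does on the shared core in this assay. No evidence is at hand that bears on this result.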